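Removing the bromo from compound 1

The source may hold more compounds than are shown below. What is called first, only, known or untested is meant among the compounds shown, and "the series" means these compounds.

Among the compounds with values here, compound 1 `O=C(Nc1ccc(-n2ncc3c(Br)cccc32)cc1)Nc1ccc(Cl)c(C(F)(F)F)c1` gives the lowest of the two numbers so far: in a functional assay on Bel-7402 cells (Homo sapiens) for cytotoxicity, read by MTT assay, with a stated time of 72 h (a lower number here means a stronger inhibitor, a higher number a weaker inhibitor), compound 1 gives 1300 nM, while compound 2 `Cc1cccc2c1cnn2-c1ccc(NC(=O)Nc2ccc(Cl)c(C(F)(F)F)c2)cc1` gives 6700 nM. Within the data shown here, the only step in hand, a 5.2-fold higher number from compound 1 to compound 2 (0.71 log units; beyond the scatter), replaces the bromo with a methyl at the same position. Compound 3 `O=C(Nc1ccc(-n2ncc3ccccc32)cc1)Nc1ccc(Cl)c(C(F)(F)F)c1` differs from compound 1 by hydrogen in place of bromo on an aromatic carbon. Among the measured compounds shown here, only that one step bears on this change; both remove the bromo, so a weakening of similar, modest size is expected, a 3.5-fold higher number from compound 1 to compound 3 (0.54 log units; beyond the scatter). Compound 3 is therefore estimated at 4500 nM, with a range from 1300 nM to 15000 nM.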

Compound 3, half-maximal inhibitory concentration: 10600 nM
Beside the measured number, compound 3's estimate is 2.4-fold (0.37 log units) below it; measured number inside the range.
By their numbers in this assay, from the lowest: compound 1; then compounds 2 and 3 (each within the scatter of the next).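

In this assay hydrogen in place of bromo gives an 8.2-fold higher number from compound 1 to compound 3 (0.91 log units; beyond the scatter) and so shows that the low number of compound 1 goes with the bromo itself, since the weakening does not depend on a methyl entering at this position. Hydrogen in place of methyl gives a 1.6-fold higher number from compound 2 to compound 3 (0.20 log units; within the scatter) and so leaves compound 2 and compound 3 not separated here. No evidence is at hand on why the bromo stands apart.

On these data alone, whether chloro, iodo, methoxy or an amine at this aromatic carbon would match the bromo remains open.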